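Chlorine Position on the Sulfonyl Aryl Ring and Receptor Binding

The source may hold more compounds than are shown below. What is called first, only, known or untested is meant among the compounds shown, and "the series" means these compounds.

Measured compounds:
compound 1 `Cc1ccccc1C(=O)NCc1ccc(CNS(=O)(=O)c2ccc(Cl)cc2)cc1`, 1 nM
compound 2 `COc1ccccc1C(=O)NCc1ccc(CNS(=O)(=O)c2cccc(Cl)c2)cc1`, 1000 nM
compound 3 `Cc1ccccc1C(=O)NCc1ccc(CNS(=O)(=O)c2ccccc2Cl)cc1`, 1000 nM

In an assay on MDA-MB-231 cells for displacement of a labelled ligand from C-X-C chemokine receptor type 4 (Homo sapiens), read by fluorescence and microscopy, with stated times of 10 min and 30 min (on this read-out lower numbers stand for an effect already at smaller amounts and higher numbers for an effect only at larger amounts of compound), compound 3 gives 1000 nM, level with compound 2 and together with it the highest number of the three; compound 1 gives 1 nM, the lowest. Within the data shown here, the one measured step that bears on the chlorine position is a 1000-fold higher number from compound 1 to compound 3 (3.00 log units; beyond the scatter), a large loss. Compound 4 `Cc1ccccc1C(=O)NCc1ccc(CNS(=O)(=O)c2cccc(Cl)c2)cc1` is not yet measured; (3-chlorophenyl in place of 2-chlorophenyl on a sulfonyl sulfur). Compound 2 also carries 3-chlorophenyl on the sulfonyl sulfur and gives 1000 nM, though it differs from compound 4 in another part of the molecule, so that comparison is only suggestive. The expected step is a 1.7-fold lower number from compound 3 to compound 4 (0.22 log units; within the scatter), roughly none beyond the scatter. Compound 4 is therefore estimated at 600 nM, within 100 nM to 3000 nM.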

Compound 4, effective concentration (reported as EC, without a stated level of effect): 100 nM
Estimate against measurement, compound 4: 6.0-fold (0.78 log units) above, within the range that was stated.
By their numbers in this assay, from the lowest: compound 1; then compound 4; then compounds 2 and 3 (each within the scatter of the next).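

In this assay, 3-chlorophenyl in place of 2-chlorophenyl gives a 10-fold lower number from compound 3 to compound 4 (1.00 log units; beyond the scatter), while 3-chlorophenyl in place of 4-chlorophenyl gives a 100-fold higher number from compound 1 to compound 4 (2.00 log units; beyond the scatter), so all three chlorine placements can now be compared on one core, with 4-chlorophenyl giving the lowest number and 2-chlorophenyl the highest. Compound 2 was also an incomplete guide to the 3-chlorophenyl compound: methyl in place of methoxy on an aromatic carbon gives a 10-fold lower number from compound 2 to compound 4 (1.00 log units; beyond the scatter), so that other part of the molecule matters too.

Going by these compounds, whether this order of positions holds for bromine or a nitrile in place of chlorine remains open. Nothing shown here explains why the chlorine position or the methyl group changes the number.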